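Urea-linked thienopyrimidines: moving the chlorine on the terminal phenyl

This account rests on a few compounds, and the source may have more. Where it says the series, first, only, none or still open, it means among the compounds named here.

Of the compounds shown here, two have been measured in a functional assay on NCI-H460 cells (Homo sapiens) for cytotoxicity, read by MTT assay, with a stated time of 72 h; a higher number here means a weaker inhibitor, a lower number a stronger inhibitor. Compound 1 `CN(C)CCNc1nc(-c2ccc(NC(=O)Nc3ccccc3Cl)cc2)nc2c(Cl)c(Cl)sc12` gives 440 nM. Compound 2 `CCN(CC)CCNc1nc(-c2ccc(NC(=O)Nc3ccc(Cl)cc3)cc2)nc2c(Cl)c(Cl)sc12` gives 320 nM. The two numbers sit within the usual scatter of each other, so compound 2 cannot be separated from compound 1 on these data, and the two differ in more than one place, so no single step can be read from them.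

Compound 3 `CCN(CC)CCNc1nc(-c2ccc(NC(=O)Nc3ccccc3Cl)cc2)nc2c(Cl)c(Cl)sc12` is not yet measured. Relative to compound 2 the change is 2-chlorophenyl in place of 4-chlorophenyl on an amide-type nitrogen. Compound 1 already carries the 2-chlorophenyl group, and its value in this assay does not stand apart from that of compound 2, so no step beyond the scatter is expected in this assay, in either direction. The step from compound 2 to compound 3 is estimated at a 1.3-fold higher number from compound 2 to compound 3 (0.10 log units; within the scatter). For compound 3 the expected value in this assay is 400 nM, with a range from 200 nM to 800 nM.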

Compound 3, half-maximal inhibitory concentration: 460 nM
Beside the measured number, compound 3's estimate is 1.2-fold (0.06 log units) below it, within the range that was stated.
By their numbers in this assay, from the lowest: compounds 2, 1 and 3 (each within the scatter of the next).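

In this assay the series now has its first comparisons that differ in one place: with the diethylamino chain held, 2-chlorophenyl in place of 4-chlorophenyl on the amide-type nitrogen gives a 1.4-fold higher number from compound 2 to compound 3 (0.16 log units; within the scatter), so this move of the chlorine does not separate the two compounds. With 2-chlorophenyl held, diethylamino in place of dimethylamino on the saturated chain carbon gives a 1.0-fold higher number from compound 1 to compound 3 (0.02 log units; within the scatter), so this change at the chain end does not separate its pair either. Nothing available bears on why both steps stay within the scatter.

Open, on these data alone, is whether 3-chlorophenyl, unsubstituted phenyl or 4-methoxyphenyl on the same nitrogen, or a pyrrolidine or a longer chain at the amine end, would give a step beyond the scatter. Also open, as far as these compounds go, is whether hydrogen or methyl could replace chlorine on the shared core without such a step.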